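The source may hold more compounds than are shown below. What is called first, only, known or untested is meant among the compounds shown, and "the series" means these compounds.

In an ADME assay on microsomes from liver (Rattus norvegicus) for metabolic stability (on this read-out lower numbers stand for a shorter-lived compound and higher numbers for a longer-lived compound), compound 3 (`CC(C)C(c1ncc[nH]1)c1ccc(-c2ccc3cccc(F)c3c2)[nH]c1=O`) gives < 0.0667 h as its reading, and this is a limit of the assay, not a number. In this assay compound 1 (`CC(C)C(c1ccc(-c2ccc3cccc(F)c3c2)[nH]c1=O)N1CCCCS1(=O)=O`) reads 0.07 h and compound 2 (`CC(C)C(Cc1nnc[nH]1)c1ccc(-c2ccc3cccc(F)c3c2)[nH]c1=O`) reads 0.1 h as measured numbers.

Compound 4 (`CC(C)C(Cc1nnn[nH]1)c1ccc(-c2ccc3cccc(F)c3c2)[nH]c1=O`) has not been measured yet, and it differs from compound 3 in one place ((1H-tetrazol-5-yl)methyl in place of 1H-imidazol-2-yl on a saturated chain carbon bound to an aromatic carbon and a saturated chain carbon). Here (1H-tetrazol-5-yl)methyl stands in place of 1H-imidazol-2-yl on a saturated chain carbon bound to an aromatic carbon and a saturated chain carbon.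

Compound 2 carries (4H-1,2,4-triazol-3-yl)methyl, which is the measured group most like the incoming one. That makes an at least 1.4-fold lower number from compound 2 to compound 3 (0.17 log units; that floor lies within the scatter) the nearest guide when read backwards, although it gives only a floor. The other two steps at this place are a 1.4-fold higher number from compound 1 to compound 2 (0.15 log units; within the scatter) and an at least 1.0-fold lower number from compound 1 to compound 3 (0.02 log units; that floor lies within the scatter) and none of the three is shown beyond the scatter.

A small change is therefore expected, with an estimated at least 1.4-fold higher number from compound 3 to compound 4 (0.17 log units; that floor lies within the scatter) that stays within the scatter. For compound 4 the estimate is 0.1 h with an expected range from 0.05 h to 0.22 h and a reading at the limit of the assay remains possible.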

Compound 4, half-life: 2.08 h
For compound 4 the middle estimate is 21-fold (1.32 log units) below the measured one; measured number outside the range, above it.
By their numbers in this assay, from the lowest: compounds 1 and 2 (each within the scatter of the next); then compound 4. At a limit, below all of these: compound 3.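

In this assay, going by these compounds alone, the closest comparison is a 21-fold higher number from compound 2 to compound 4 (1.32 log units; beyond the scatter): 1H-tetrazol-5-yl stands in place of 4H-1,2,4-triazol-3-yl on the same chain, so exchanging one five-membered aromatic ring for another can produce a large change here, which none of the earlier steps at this place showed beyond the scatter. Compound 4 also stands clear of the group with the six-membered non-aromatic ring, with a 30-fold higher number from compound 1 to compound 4 (1.47 log units; beyond the scatter). The remaining step, an at least 31-fold higher number from compound 3 to compound 4 (1.49 log units; beyond the scatter), is only a floor, because the reading it starts from is a limit: the limit of < 0.0667 h in this assay, at which 1 of the 4 values shown sits.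

Compound 4 is the only compound shown with a tetrazole, so the data cannot tell whether the large step belongs to that ring alone or depends on its methyl link to the chain, and 1H-tetrazol-5-yl set directly on the saturated chain carbon, or on a longer chain, would separate the two. On these data alone, how a carboxylic acid in the same place would read also stays open. Nothing shown here measures what lies behind the step.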